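Plasma stability of anilides in the quinazolinone propanamide series

The source may report more compounds than this note shows. Statements on the series, on what has been measured and on what is new or still open speak of the compounds shown alone.

Three compounds of the shared core have been run in an ADME assay on a cell-free system (plasma, Mus musculus, strain CD-1) for metabolic stability, read by LC-MS, tested at 1 uM; a lower number here means that the compound disappears faster, a higher number that the compound lasts longer. Compound 1 `COc1ccccc1NC(=O)c1ccc(NC(=O)CCc2nc3ccccc3c(=O)[nH]2)cc1C` gives 0.717 h in this assay. Compound 3 `COc1ccccc1N(C)C(=O)c1ccc(NC(=O)CCc2nc3ccccc3c(=O)[nH]2)cc1` gives 0.633 h in this assay, and the two numbers lie within the scatter of each other, so no order between compound 1 and compound 3 is claimed. Among the measured compounds shown here, compound 2 `COc1ccccc1NC(=O)[C@H]1CC[C@@H](NC(=O)CCc2nc3ccccc3c(=O)[nH]2)CC1` returns only a limit in this assay, > 16.6 h; this is the one value on the series that is a limit rather than a number (the limit of > 16.6 h in this assay, at which 1 of the 3 values shown sits).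

Compound 4 `COc1cccc(C)c1NC(=O)c1ccc(NC(=O)CCc2nc3ccccc3c(=O)[nH]2)cc1` has not yet been measured. The change from compound 3 is a group of 10 heavy atoms (8 carbon, 1 nitrogen, 1 oxygen; one six-membered aromatic ring of carbon only) in place of a group of 10 heavy atoms (8 carbon, 1 nitrogen, 1 oxygen; one six-membered aromatic ring of carbon only), on a carbonyl carbon.

No step between measured compounds is shown, so the size of this step can only be guessed. Both anilides measured so far are short-lived in this assay, and the change keeps the anilide. Compound 4 is expected at 0.8 h, between 0.35 h and 2 h, an expected step of a 1.3-fold higher number from compound 3 to compound 4 (0.10 log units; within the scatter) that is judged not beyond the scatter.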

Compound 4, half-life: 4.5 h
Compound 4: the middle estimate sits 5.6-fold (0.75 log units) below what was measured, and the stated range ends below it.
By their numbers in this assay, from the lowest: compounds 3 and 1 (each within the scatter of the next); then compound 4. At a limit, above all of these: compound 2.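

In this assay, the change on the carbonyl carbon gives a 7.1-fold higher number from compound 3 to compound 4 (0.85 log units; beyond the scatter), although the two compounds hold the same atoms, joined differently. An anilide on this core is therefore not short-lived as such: the entering group has 1 hydrogen-bond donor where (2-methoxyphenyl)(methyl)amino has 0, and this one swap is enough to take the half-life beyond the scatter. Nothing shown bears on the reason for this step.

This single step alters the donor count and the arrangement of the atoms together, so the compounds shown cannot separate the two. Also open, on these data alone, is how the half-life would respond to a chlorine atom or an ethyl group in place of the methyl on the aromatic ring of compound 4.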